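A Methyl Group Added to Compound 3

The compounds below may be only part of what the source reports. "The series", "measured", "known", "first", "only" and "open" are said of these compounds alone.

In a functional assay on MCF7 cells (Homo sapiens) for antiproliferative activity, read by MTT assay, with a stated time of 48 h (a lower number here means a stronger inhibitor, a higher number a weaker inhibitor), compound 1 `Cc1ccc2nc(NC(c3cn(-c4ccccc4)nc3-c3cccc([N+](=O)[O-])c3)c3c(O)ccc4ccccc34)sc2c1` gives 38400 nM, compound 2 `Cc1ccc2nc(NC(c3cn(-c4ccccc4)nc3-c3cccc(Cl)c3)c3c(O)ccc4ccccc34)sc2c1` gives 49700 nM and compound 3 `Oc1ccc2ccccc2c1C(Nc1nc2ccccc2s1)c1cn(-c2ccccc2)nc1-c1ccccc1` gives 48900 nM. Compound 3 thus stands within the scatter of both other compounds. Compound 4 `Cc1ccc(-c2nn(-c3ccccc3)cc2C(Nc2nc3ccccc3s2)c2c(O)ccc3ccccc23)cc1` has methyl in place of hydrogen on an aromatic carbon, para to a large group: methyl in place of hydrogen on an aromatic carbon. Within the data shown here, the only measured step is a different exchange, chloro in place of nitro, a 1.3-fold higher number from compound 1 to compound 2 (0.11 log units; within the scatter), and it stays within the scatter. Among the measured compounds shown here, no measured step adds a methyl, so this one bears only indirectly, and no shift beyond the scatter is expected in this assay. The expected change is a 1.1-fold lower number from compound 3 to compound 4 (0.04 log units; within the scatter). Compound 4 is estimated at 45000 nM, with an expected range from 20000 nM to 90000 nM.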

Compound 4, half-maximal inhibitory concentration: 13100 nM
Estimate against measurement, compound 4: 3.4-fold (0.54 log units) above; the whole stated range lies above it.
By their numbers in this assay, from the lowest: compound 4; then compounds 1, 3 and 2 (each within the scatter of the next).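

In this assay, the change from phenyl to 4-methylphenyl gives a 3.7-fold lower number from compound 3 to compound 4 (0.57 log units; beyond the scatter), the first step among these compounds to lie beyond the scatter. It shows that this place on the six-membered aromatic ring responds to a single added methyl, which the earlier exchange of chloro for nitro, a 1.3-fold higher number from compound 1 to compound 2 (0.11 log units; within the scatter), gave no sign of at its own place. Nothing available explains this step.

On these data alone, whether an ethyl, a methoxy or an amine in the same place would lower the number further, or give the step back, stays open. Also open, as far as these compounds go, is whether a methyl elsewhere on this ring would give a similar step.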